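The source may hold more compounds than are shown below. What is called first, only, known or untested is meant among the compounds shown, and "the series" means these compounds.

Measured in a functional assay on MC-38 cells (Mus musculus) for antiproliferative activity, read by CCK-8 assay, with a stated time of 48 h; a higher number here means a weaker inhibitor, a lower number a stronger inhibitor:
- compound 1 `COc1ccc(/C=C\c2cc(OC)c(OC)c(OC)c2)cc1OCc1ccc(CNC(C)(C)C(=O)O)cc1` gives > 10000 nM (a limit)
- compound 2 `COc1ccc(/C=C\c2cc(OC)c(OC)c(OC)c2)cc1OCc1ccc(C=O)cc1` gives 900 nM
- compound 3 `COc1ccc(/C=C\c2cc(OC)c(OC)c(OC)c2)cc1OCc1ccc(CN2CCCC[C@H]2C(=O)O)cc1` gives > 10000 nM (a limit)

For the measured compounds named here, compound 2 holds the only actual number in this small set. The other two results are limits and not numbers: the limit of > 10000 nM in this assay, at which 2 of the 3 values shown sit. Compound 4 `COc1ccc(/C=C\c2cc(OC)c(OC)c(OC)c2)cc1OCc1ccc(CN2CCCCC2C(=O)O)cc1` has not yet been measured. It differs from compound 2 as follows: (2-carboxypiperidin-1-yl)methyl in place of formyl on an aromatic carbon. In words, it carries (2-carboxypiperidin-1-yl)methyl in place of formyl on an aromatic carbon.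

The closest evidence is the same replacement in compound 3, which gave an at least 11-fold higher number from compound 2 to compound 3 (1.04 log units; beyond the scatter). Compound 1 points the same way, since its amino acid side chain gave way to formyl in an at least 11-fold lower number from compound 1 to compound 2 (1.04 log units; beyond the scatter). The remaining comparison, a step that the two limits leave unreadable from compound 1 to compound 3, adds nothing on size. A large step towards a higher number is therefore expected in this assay, and compound 4 may well report only as a limit. The expected change is a 17-fold higher number from compound 2 to compound 4 (1.22 log units; beyond the scatter). For compound 4 the estimated value is 15000 nM, with an expected range of 5000 nM to 40000 nM.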

Compound 4, half-maximal inhibitory concentration: 5400 nM
Estimate against measurement, compound 4: 2.8-fold (0.44 log units) above; the measured number falls inside the stated range.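

In this assay, for the compounds shown here, compound 4 gives the first actual number for an amino acid side chain at this place, on an aromatic carbon para to a large group, so the cost of (2-carboxypiperidin-1-yl)methyl in place of formyl can now be sized: a 6.0-fold higher number from compound 2 to compound 4 (0.78 log units; beyond the scatter). Against the two compounds that report only a limit, the steps are an at least 1.8-fold lower number from compound 3 to compound 4 (0.26 log units; that floor lies within the scatter) and an at least 1.8-fold lower number from compound 1 to compound 4 (0.26 log units; that floor lies within the scatter), and neither floor goes beyond the scatter. Compounds 3 and 4 share the same atoms and bonds, and what separates them is this: the fact that one of compounds 3 and 4 is drawn with a defined configuration and the other without, at the place where they differ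

From the compounds shown here alone, what the defined stereocentre contributes stays open, since the result for compound 3 is only a limit: the limit of > 10000 nM in this assay, at which 2 of the 4 values shown sit. Also open is how a piperidin-1-ylmethyl group without the carboxylic acid, or a methyl ester in place of that acid, would read at this position.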